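This account rests on a few compounds, and the source may have more. Where it says the series, first, only, none or still open, it means among the compounds named here.

Two compounds measured in a functional assay on CHO cells for agonist activity at Melanocortin receptor 4 (Homo sapiens), read by a luciferase reporter, with a stated time of 4 h (a higher number here means that more compound is needed for the effect, a lower number that less compound is needed), share a core, which in compound 1 `COc1ccc(N(C(=O)CN2C=CN(c3ccccc3)C(=O)C(Cc3n[nH]c4ccccc34)C2=O)C(C)C)cc1` carries a methoxyphenyl group together with an isopropyl group on the amide nitrogen, and in compound 2 `O=C1C(Cc2n[nH]c3ccccc23)C(=O)N(c2ccccc2)C=CN1CC(=O)N1CCCCc2ccccc21` carries a ring-fused amine in the same place. In this assay compound 1 gives 708 nM, and compound 2 gives 324 nM, so compound 2 stands at the lower of the two numbers; the step of a 2.2-fold lower number from compound 1 to compound 2 (0.34 log units; beyond the scatter) is modest but beyond the scatter.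

Compound 3 `CC(C)N(C(=O)CN1C=CN(c2ccccc2)C(=O)C(Cc2n[nH]c3ccccc23)C1=O)c1ccccc1` has not yet been measured in this assay. It differs from compound 2 in one place: a group of 10 heavy atoms (9 carbon, 1 nitrogen; one six-membered aromatic ring of carbon only) in place of a group of 11 heavy atoms (10 carbon, 1 nitrogen; one six-membered aromatic ring of carbon only, one seven-membered non-aromatic ring with 1 hetero atom), on a carbonyl carbon. This change largely reverses the step from compound 1 to compound 2, except that the methoxy group of compound 1 is absent in compound 3. Going by the values given here, only the step from compound 1 to compound 2 bears on this change, and it was modest; going the opposite way, a modest rise in the number in this assay is expected for compound 3, a 1.9-fold higher number from compound 2 to compound 3 (0.27 log units; within the scatter). The expected value for compound 3 is therefore 600 nM, within a range of 250 nM to 1500 nM.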

Compound 3, half-maximal effective concentration: 3240 nM
Compound 3: the middle estimate sits 5.4-fold (0.73 log units) below what was measured; the whole stated range lies below it.
By their numbers in this assay, from the lowest: compound 2; then compound 1; then compound 3.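

In this assay, the group on this carbonyl carbon matters more than the first pair suggested: isopropyl(phenyl)amino in place of the ring-fused amine gives a 10-fold higher number from compound 2 to compound 3 (1.00 log units; beyond the scatter). The methoxy group can now be judged on its own, since hydrogen in place of methoxy on an aromatic carbon gives a 4.6-fold higher number from compound 1 to compound 3 (0.66 log units; beyond the scatter), so the modest gap between the first two compounds depends on methoxy being present. No measurement shown here explains either step.

Going by these compounds, it remains open whether methoxy is special or whether another group on that aromatic carbon, such as a chlorine atom or a hydroxyl group, would bring the number down as well, and whether adding methoxy to the aromatic ring of the ring-fused amine would lower the number further. Also open, on these data alone, is how much the isopropyl group itself contributes, which a compound with an ethyl or cyclopropyl group in its place on the amide nitrogen could show.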